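Cyclohexyl to 4-chlorophenyl on the way to compound 4

A few compounds are considered here, and "the series" means these few. Any claim that something is new, unique, unknown or untested is made for them only; others in the source may bear on it.

Values in a functional assay on A549 cells (Homo sapiens) for antiproliferative activity, read by MTT assay, with a stated time of 72 h; on this read-out higher numbers stand for weaker inhibition and lower numbers for stronger inhibition:
- compound 1 `CCCNc1ccnc(Nc2ccc(NC(=O)Nc3ccc(Cl)c(C(F)(F)F)c3)cc2)n1` gives 7320 nM
- compound 2 `O=C(Nc1ccc(Nc2nccc(Nc3ccccc3)n2)cc1)Nc1ccc(Cl)c(C(F)(F)F)c1` gives > 50000 nM as a limit
- compound 3 `O=C(Nc1ccc(Nc2nccc(NC3CCCC3)n2)cc1)NC1CCCCC1` gives 5320 nM
- compound 4 `O=C(Nc1ccc(Cl)cc1)Nc1ccc(Nc2nccc(NC3CCCC3)n2)cc1` is not yet measured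

In this assay compound 3 at 5320 nM and compound 1 at 7320 nM lie within the scatter of each other. Compound 2 reads > 50000 nM as a limit of the assay.

Compound 4 differs from compound 3 in one place (4-chlorophenyl in place of cyclohexyl on an amide-type nitrogen), with 4-chlorophenyl in place of cyclohexyl on an amide-type nitrogen. For the measured compounds named here, one measured step bears on this, though at another place: an at least 6.8-fold higher number from compound 1 to compound 2 (0.83 log units; beyond the scatter) with phenyl in place of propyl on a nitrogen on an aromatic ring. Against a large loss, compound 1 carries an aromatic ring on the amide-type nitrogen and still gives 7320 nM as a measured number. A rise smaller than that measured step is therefore expected in this assay. The expected change is a 1.7-fold higher number from compound 3 to compound 4 (0.23 log units; within the scatter) and may not clear the scatter. Compound 4 is estimated at 9000 nM with an expected range of 3000 nM to 27000 nM.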

Compound 4, half-maximal inhibitory concentration: 11800 nM
For compound 4 the middle estimate is 1.3-fold (0.12 log units) below the measured one; measured number inside the range.
By their numbers in this assay, from the lowest: compounds 3, 1 and 4 (each within the scatter of the next, the first and the last beyond it). At a limit, above all of these: compound 2.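

In this assay the amide-type nitrogen turns out to be a place that responds: 4-chlorophenyl in place of cyclohexyl gives a 2.2-fold higher number from compound 3 to compound 4 (0.35 log units; beyond the scatter). For the compounds shown here, the only earlier step lay at a different place, the nitrogen on an aromatic ring, so this is the first reading on the amide-type nitrogen with the rest of the molecule held unchanged. The step is modest, and nothing measured here gives a reason for it.

On these data alone, whether the chlorine or the aromatic ring itself carries the change remains open, and plain phenyl on the same nitrogen would separate the two. Also open, as far as these compounds go, is how that nitrogen tolerates a longer chain or a chain ending in an amine, and whether the same change holds with the propylamino group of compound 1 in the molecule.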